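A few compounds are considered here, and "the series" means these few. Any claim that something is new, unique, unknown or untested is made for them only; others in the source may bear on it.

Measured in a functional assay on NCI-H522 cells (Homo sapiens) for cytotoxicity, with a stated time of 3 days (a higher number here means a weaker inhibitor, a lower number a stronger inhibitor), as follows:
- compound 1 `CC#Cc1nc(C(=O)OCC)cs1` gives > 40000 nM (a limit)
- compound 2 `C#CCNC(=O)c1csc(C#Cc2ccccc2)n1` gives > 40000 nM (a limit)
- compound 3 `C#Cc1nc(C(=O)OCC)cs1` gives 2670 nM as a true number

For the measured compounds named here, compound 3 holds the only number in the set. Against it stands the limit of > 40000 nM in this assay, at which 2 of the 3 values shown sit, in this series.

The next change is phenyl in place of hydrogen on a triple-bonded carbon, giving compound 4 `CCOC(=O)c1csc(C#Cc2ccccc2)n1` as the unmeasured member. Going by the values given here, the one measured step at this carbon is an at least 14-fold lower number from compound 1 to compound 3 (1.17 log units; beyond the scatter) and it is large. Compound 4 differs elsewhere from compound 2, which also has phenyl there and gives only the limit > 40000 nM in this assay as its reading. The estimated move is a 10-fold higher number from compound 3 to compound 4 (1.02 log units; beyond the scatter) towards a higher number, and it may well end at a limit. In this assay compound 4 is expected at 28000 nM (estimated range 8000 nM to 80000 nM).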

Compound 4, half-maximal inhibitory concentration: > 40000 nM
Compound 4: only a limit was reported; the forecaster's own chance of this, stated with the estimate: 60%; at least 1.4-fold (0.15 log units) between middle value and limit.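

Phenyl in place of hydrogen on the triple-bonded carbon gives an at least 14-fold higher number from compound 3 to compound 4 (1.17 log units; beyond the scatter) in this assay, so a second, much larger group on this carbon also loses the true number that compound 3 holds. For the compounds shown here, with methyl in compound 1 and phenyl in compound 4, hydrogen is the only group on this carbon with a true number, and most readings sit at the limit: the limit of > 40000 nM in this assay, at which 3 of the 4 values shown sit. The steps from compound 2 and from compound 1 to compound 4 cannot be read, as both ends are limits.

Going by these compounds, it remains open whether a hydroxymethyl or an aminomethyl on this carbon would keep a true number. Also open, on these data alone, is whether a carboxylic acid can replace the ethoxy-bearing ester while hydrogen stays on the triple-bonded carbon.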